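The source may report more compounds than this note shows. Statements on the series, on what has been measured and on what is new or still open speak of the compounds shown alone.

Of the compounds shown here, three built on one shared core have been tested in an ADME assay on L02 cells (Homo sapiens) for cytotoxicity, read by MTT assay, with a stated time of 48 h; a lower number here means a stronger inhibitor, a higher number a weaker inhibitor. Compound 1 `CCn1c(C(=O)NCCN(C)C)ccc1C(CC)(CC)c1ccc(OCC(=O)C(C)(C)C)c(C)c1` gives 2500 nM. Compound 2 `CCN(CC)CCCNC(=O)c1ccc(C(CC)(CC)c2ccc(OCC(=O)C(C)(C)C)c(C)c2)n1CC` gives 2300 nM, and the step of a 1.1-fold lower number from compound 1 to compound 2 (0.04 log units; within the scatter) shows the two values cannot be told apart. Compound 3 `CCN(CC)CCCNC(=O)c1ccc(C(CC)(CC)c2ccc(OCC(O)C(C)(C)C)c(C)c2)n1CC` gives 2500 nM, and the step of a 1.1-fold higher number from compound 2 to compound 3 (0.04 log units; within the scatter) likewise stays inside the scatter. Compound 3 therefore stands level with compound 1 at the digits shown, and the gap to compound 2 is too small to count as a change.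

Compound 4 `CC[C@@H](C)[C@H](NC(=O)c1ccc(C(CC)(CC)c2ccc(OCC(O)C(C)(C)C)c(C)c2)n1CC)C(=O)O` has not yet been measured. It differs from compound 3 by one change: 1-carboxy-2-methylbutyl in place of 3-(diethylamino)propyl on an amide-type nitrogen. Neither measured step covers this kind of exchange. The step from compound 1 to compound 2 altered only the amine at the end of the chain, and the step from compound 2 to compound 3 altered the group bound to the oxygen on the aromatic ring; both were within the scatter. Among the measured compounds shown here, the new change replaces the whole chain on the amide-type nitrogen, so no measured step gives a guide to its size.

With nothing pointing either way, compound 4 is expected to show a step of no change at the digits printed from compound 3 to compound 4 (within the scatter), that is, no change beyond the scatter. The estimate for compound 4 in this assay is 2500 nM, with a range from 800 nM to 8000 nM.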

Compound 4, half-maximal inhibitory concentration: 1400 nM
Compound 4: the middle estimate sits 1.8-fold (0.25 log units) above what was measured; measured number inside the range.
By their numbers in this assay, from the lowest: compounds 4, 2, 1 and 3 (each within the scatter of the next).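

In this assay, replacing the whole 3-(diethylamino)propyl chain on the amide-type nitrogen with 1-carboxy-2-methylbutyl gives a 1.8-fold lower number from compound 3 to compound 4 (0.25 log units; within the scatter) and so stays inside the scatter. The earlier steps shown here changed only the amine at the end of the chain or the group on the oxygen, whereas here the amine is gone altogether and a carboxylic acid with two defined stereocentres takes its place, so this position accepts a much larger exchange than those steps tested, with no change that can be told from scatter in this assay. Nothing available explains why these two different chains give values that cannot be told apart.

Since the carboxylic acid and the branched butyl chain enter together, compound 4 cannot show what each contributes, and a methyl ester or a primary amide in place of the acid, or an unbranched chain carrying the same acid, would help separate them. Also open, going by these compounds, are the mirror-image arrangements at the two stereocentres and whether the same chain behaves alike with the carbonyl of compound 2 in place of the hydroxyl group.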